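Aryl swap on the triazole nitrogen of the spirooxindole series

The source may hold more compounds than are shown below. What is called first, only, known or untested is meant among the compounds shown, and "the series" means these compounds.

Compound 1 `Cc1cc(C)cc(-n2nncc2CN2C(=O)C3(C(C#N)=C(N)Oc4c3c3nc5ccccc5nc3c3ccccc43)c3ccccc32)c1` sits at the limit of a functional assay on A549 cells (Homo sapiens) for antiproliferative activity, read by MTT assay, with a stated time of 48 h (on this read-out lower numbers stand for stronger inhibition and higher numbers for weaker inhibition), reporting > 50000 nM, which is a limit and not a number (the limit of > 50000 nM in this assay, at which 1 of the 2 values shown sits). For the measured compounds named here, compound 2 `N#CC1=C(N)Oc2c(N)cc3nc4ccccc4nc3c2C12C(=O)N(Cc1cnnn1-c1cccc(C(F)(F)F)c1)c1ccccc12` is the only compound with a number in this assay, giving 5400 nM. Compound 3 `Cc1ccc(-n2nncc2CN2C(=O)C3(C(C#N)=C(N)Oc4c(N)cc5nc6ccccc6nc5c43)c3ccccc32)cc1Cl` carries the change (3-chloro-4-methylphenyl in place of 3-(trifluoromethyl)phenyl on an aromatic nitrogen). Going by the values given here, no step between measured compounds is available, so the change is expected to stay within the usual scatter, with no clear direction. Compound 3 is therefore estimated at 5000 nM, between 2000 nM and 15000 nM, a step of a 1.1-fold lower number from compound 2 to compound 3 (0.03 log units; within the scatter).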

Compound 3, half-maximal inhibitory concentration: 11800 nM
Compound 3: middle estimate off by 2.4-fold (0.37 log units), on the low side; the range from low to high includes it.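

In this assay, for the compounds shown here, the swap of 3-(trifluoromethyl)phenyl for 3-chloro-4-methylphenyl on the aromatic nitrogen gives a 2.2-fold higher number from compound 2 to compound 3 (0.34 log units; beyond the scatter) and is the first readable step. This position therefore responds to the aryl substitution, though modestly, and both aryl groups still return a number and not a limit. Nothing at hand accounts for the step. A single pair cannot separate the loss of trifluoromethyl from the gain of chlorine and methyl. Also open, on these data alone, is how unsubstituted phenyl, or an aryl group bearing an amine or a carboxylic acid, reads here.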